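The compounds below may be only part of what the source reports. "The series", "measured", "known", "first", "only" and "open" are said of these compounds alone.

Compound 1 `CCSC(=S)SCC(=O)c1ccc(C)cc1` gives 3980 nM
Compound 2 `[C-]#[N+]c1ccc(C(=O)CSC(=S)SCC)cc1` gives 7940 nM

In a functional assay on HeLa cells (Homo sapiens) for antiproliferative activity, read by resazurin assay (on this read-out higher numbers stand for weaker inhibition and lower numbers for stronger inhibition), compound 2 at 7940 nM lies within the usual scatter of compound 1. Compound 3 `CCSC(=S)SCC(=O)c1ccc(OC)cc1` carries a methoxy on an aromatic carbon in place of the group that compound 2 holds there, a change counted as a group of 2 heavy atoms (1 carbon, 1 oxygen; no ring) in place of a group of 2 heavy atoms (1 carbon, 1 nitrogen; no ring), on an aromatic carbon in full. Among the compounds with values here, the only measured step at that place is a 2.0-fold higher number from compound 1 to compound 2 (0.30 log units; within the scatter) and it stayed within the scatter, so no step beyond the scatter is expected here. The expected step is a 1.4-fold lower number from compound 2 to compound 3 (0.16 log units; within the scatter) and it stays within the scatter. For compound 3 the estimated value is 5500 nM with an expected range from 2200 nM to 14000 nM as its likely span.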

Compound 3, half-maximal inhibitory concentration: 2510 nM
The estimate for compound 3 lay 2.2-fold (0.34 log units) above the measured number; low and high end bracket the measured number.
By their numbers in this assay, from the lowest: compounds 3, 1 and 2 (each within the scatter of the next, the first and the last beyond it).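

In this assay, within the data shown here, methoxy in place of the group with the triple bond gives a 3.2-fold lower number from compound 2 to compound 3 (0.50 log units; beyond the scatter) and this is the first step at this position to pass beyond the scatter, so what sits on this aromatic carbon can matter. Methoxy in place of methyl gives a 1.6-fold lower number from compound 1 to compound 3 (0.20 log units; within the scatter) and leaves those two compounds unranked. Nothing at hand explains these steps. From the compounds shown here alone, whether an amine, a carboxylic acid or a longer chain at this place would go further in either direction stays open. So does whether the ethyl chain on the sulfur matters.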